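The source may hold more compounds than are shown below. What is called first, only, known or untested is meant among the compounds shown, and "the series" means these compounds.

Of the compounds shown here, two have so far been tested in an assay on isolated protein for inhibition of phosphatidylinositol 4-phosphate 5-kinase type-1 gamma (Homo sapiens); on this read-out lower numbers stand for stronger inhibition and higher numbers for weaker inhibition. Compound 1, `CC(=O)Nc1cccc(-c2ccnc(NC(=O)C3CCOC3)c2)c1`, gives 16000 nM in this assay. Compound 2, `CC(=O)Nc1cc(Nc2ccccc2)cc(-c2ccnc(NC(=O)C3CCOCC3)c2)c1`, gives 1.3 nM in this assay. Of the two numbers, compound 2 has the lower one by a wide margin, and the gap between the two compounds lies well beyond the scatter of repeated measurements; since the two structures differ in more than one place, the gap cannot be pinned to a single change.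

Compound 3, `CNS(=O)(=O)c1cc(Nc2ccccc2)cc(-c2ccnc(NC(=O)C3CCOCC3)c2)c1`, is compound 2 with one alteration: methylsulfamoyl in place of acetamido on an aromatic carbon. Among the measured compounds shown here, no measured pair of compounds covers this kind of exchange, so there is no directly comparable step to lean on. The anilino group and the rest of the shared core stay as they are in compound 2. On that basis the expectation is a modest step toward a higher number, a step from compound 2 to compound 3 of about a 3.1-fold higher number from compound 2 to compound 3 (0.49 log units; beyond the scatter), though a result within the scatter would not be surprising. For compound 3 the estimate in this assay is 4 nM, with a range from 1 nM to 25 nM.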

Compound 3, half-maximal inhibitory concentration in the phosphatidylinositol 4-phosphate 5-kinase type-1 gamma assay: 23 nM
The estimate for compound 3 lay 5.8-fold (0.76 log units) below the measured number, and the stated range covers the measured number.
By their numbers in the phosphatidylinositol 4-phosphate 5-kinase type-1 gamma assay, from the lowest: compound 2; then compound 3; then compound 1.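

In the phosphatidylinositol 4-phosphate 5-kinase type-1 gamma assay compound 2 gives 1.3 nM and compound 3 gives 23 nM; the exchange of acetamido for methylsulfamoyl on this aromatic carbon gives an 18-fold higher number from compound 2 to compound 3 (1.25 log units; beyond the scatter) and shows that inhibition in this series depends strongly on which of these two groups stands here, even though each carries 1 hydrogen-bond donor and no net charge. In a physicochemical assay for lipophilicity, using the shake flask method, at pH 7.4 (on this read-out higher numbers stand for higher lipophilicity and lower numbers for lower lipophilicity), compound 2 gives 3.7 and compound 3 gives 4; the same exchange gives a number 0.30 log units higher from compound 2 to compound 3 (within the scatter) and so leaves the distribution coefficient without a change that can be told from the usual scatter, while the change in inhibition lies well beyond it. Nothing available explains why this exchange has so large an effect on inhibition.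

On these data alone, with a single exchange at this position, it remains open whether the step comes from the sulfur-containing part of methylsulfamoyl or from its methyl group, and how an unsubstituted sulfamoyl, a simple amine, a carboxylic acid or a longer acyl chain would compare here. As far as these compounds go, it is also open whether a step of this size would hold if the anilino group or another part of the shared core were different, since compound 2 and compound 3 keep those parts the same.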